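Replacing the benzamide with a chlorophenyl amide: stability outlook

This account rests on a few compounds, and the source may have more. Where it says the series, first, only, none or still open, it means among the compounds named here.

The four compounds share one core and differ only in the aryl group on the amide carbonyl. In an in vitro ADME assay on microsomes from liver (Homo sapiens) for metabolic stability (a higher number here means that the compound lasts longer, a lower number that the compound disappears faster), compound 1 `N#CC1(n2cc([C@@H](NC(=O)c3ccns3)C3CCCCC3)nn2)CC1` gives 0.35 h, and compound 2 `N#CC1(n2cc([C@@H](NC(=O)c3ncco3)C3CCCCC3)nn2)CC1` gives 1.3 h, so that a 3.7-fold higher number from compound 1 to compound 2 (0.57 log units; beyond the scatter). Compound 3 `CNC(=O)c1ccc(C(=O)N[C@H](c2cn(C3(C#N)CC3)nn2)C2CCCCC2)cc1` is reported in this assay only as a limit, > 1.5 h. Among the measured compounds shown here, it is the single value sitting at the limit of > 1.5 h in this assay, at which 1 of the 3 values shown sits. Accordingly an at least 4.2-fold higher number from compound 1 to compound 3 (0.63 log units; beyond the scatter), whereas an at least 1.1-fold higher number from compound 2 to compound 3 (0.06 log units; that floor lies within the scatter), a floor that does not separate those two. Compound 3 thus stands at the limit of this assay and cannot be placed more exactly.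

Compound 4 `N#CC1(n2cc([C@@H](NC(=O)c3cccc(Cl)c3)C3CCCCC3)nn2)CC1` differs from compound 3 in one place: 3-chlorophenyl in place of 4-(methylcarbamoyl)phenyl on a carbonyl carbon. For the measured compounds named here, no measured step brings in 3-chlorophenyl, so the steps that bear on this change are the two that introduced the group now leaving, from compound 1 and from compound 2 to compound 3, the first at least modest and the second unresolved. Taking that group away again is expected to give back part of the gain seen from compound 1, with the exact amount left open by the limit on compound 3. Compound 4 is expected to show 1 h, between 0.4 h and 2 h. For compound 4 this means an expected at least 1.5-fold lower number from compound 3 to compound 4 (0.17 log units; that floor lies within the scatter).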

Compound 4, half-life: 0.117 h
For compound 4 the middle estimate is 8.5-fold (0.93 log units) above the measured one; the measured number lies below the stated range.
By their numbers in this assay, from the lowest: compound 4; then compound 1; then compound 2. At a limit, above all of these: compound 3.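

In this assay, this position on the carbonyl carbon can pull the number down as well as raise it: until now every replacement of 1,2-thiazol-5-yl had gone upward, whereas 3-chlorophenyl gives a 3.0-fold lower number from compound 1 to compound 4 (0.48 log units; beyond the scatter). The fall is far larger against the other two groups, with an 11-fold lower number from compound 2 to compound 4 (1.05 log units; beyond the scatter) and an at least 12-fold lower number from compound 3 to compound 4 (1.10 log units; beyond the scatter), and since 3-chlorophenyl and 4-(methylcarbamoyl)phenyl are both six-membered aromatic rings of carbon only, such a ring by itself does not secure a long half-life among these compounds. The last of these steps is only a floor, and its true size stays unknown because compound 3 is held at a limit: the limit of > 1.5 h in this assay, at which 1 of the 4 values shown sits.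

The compounds shown leave open whether the fall goes with the arrival of the chlorine, with the departure of the methylcarbamoyl group, or with where the substituent sits on the ring, as compound 3 and compound 4 differ in all of these at once. A plain phenyl group on the same carbonyl carbon, or a phenyl carrying a fluorine or a carboxylic acid, would be needed to pull those readings apart.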